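From anilino to (oxolan-3-yl)amino on the chain

The source may hold more compounds than are shown below. What is called first, only, known or untested is meant among the compounds shown, and "the series" means these compounds.

In a functional assay on SK-OV-3 cells (Homo sapiens) for inhibition, read by CCK-8 assay, with a stated time of 70 h (on this read-out higher numbers stand for weaker inhibition and lower numbers for stronger inhibition), compound 3 (`c1ccc(COc2ccc(OCCOCCNc3ccccc3)cc2)cc1`) reports only a limit, > 100000 nM in this read-out. Compound 1 (`c1ccc(COc2ccc(OCCOCCOC3CCCC3)cc2)cc1`) also reports only a limit, > 100000 nM again. Compound 2 (`OCCOCCOCCOc1ccc(OCc2ccccc2)cc1`) gives a number, 59400 nM and the only one in the set. The series therefore rests largely on the limit of > 100000 nM in this assay, at which 2 of the 3 values shown sit, as its evidence.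

Compound 4 (`c1ccc(COc2ccc(OCCOCCNC3CCOC3)cc2)cc1`) carries oxolan-3-yl in place of phenyl on an amine nitrogen is the whole difference.

Within the data shown here, three measured steps bear on it only indirectly, since each exchanges a whole chain end: an at least 1.6-fold lower number from compound 1 to compound 2 (0.22 log units; that floor lies within the scatter) and an at least 1.6-fold higher number from compound 2 to compound 3 (0.22 log units; that floor lies within the scatter) while a step that the two limits leave unreadable from compound 1 to compound 3 remains open. None isolates this exchange on the amine nitrogen. Any expected movement in this assay is therefore small, towards lower numbers at most, and rests on compound 2 at 59400 nM as the sole number available. A further limit remains quite possible.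

The step expected is an at least 1.3-fold lower number from compound 3 to compound 4 (0.12 log units; that floor lies within the scatter) as an estimate only. For compound 4 the estimated value is 75000 nM with an expected range of 30000 nM to 150000 nM in this read-out.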

Compound 4, half-maximal inhibitory concentration: 48000 nM
Beside the measured number, compound 4's estimate is 1.6-fold (0.19 log units) above it; measured number inside the range.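

In this assay, among these compounds, replacing phenyl with oxolan-3-yl on the amine nitrogen gives the first step at this position that can be read as beyond the scatter (an at least 2.0-fold lower number from compound 3 to compound 4 (0.31 log units; beyond the scatter)). The same holds against the cyclopentyloxy chain end (an at least 2.0-fold lower number from compound 1 to compound 4 (0.31 log units; beyond the scatter)), whereas the (oxolan-3-yl)amino and 2-hydroxyethoxy chain ends cannot be told apart (a 1.2-fold lower number from compound 2 to compound 4 (0.09 log units; within the scatter)). The first two steps are floors, since their starting compounds give limits and not numbers: (the limit of > 100000 nM in this assay, at which 2 of the 4 values shown sit).

From the compounds shown here alone, it remains open whether the step follows from the ring oxygen of oxolan-3-yl or from the loss of phenyl, a separation that a cyclopentylamino chain end would allow. Also open, going by these compounds, is whether a longer chain or a terminal carboxylic acid would move the number beyond the scatter from compound 2 and compound 4.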